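From methyl to trifluoromethyl on compound 1

The compounds below may be only part of what the source reports. "The series", "measured", "known", "first", "only" and "open" are said of these compounds alone.

compound 1 `Cc1ccc(-c2nn(-c3ccccc3)cc2-c2nc3ccccc3n2S(=O)(=O)c2ccccc2)cc1`: 830 nM
compound 2 `Cc1ccc(-c2nn(-c3ccccc3)cc2-c2nc3ccccc3n2S(=O)(=O)c2ccc(F)cc2)cc1`: 5270 nM

Both values come from a functional assay on MCF7 cells (Homo sapiens) for antiproliferative activity, read by MTT assay, with a stated time of 24 h (a lower number here means a stronger inhibitor, a higher number a weaker inhibitor), where compound 1 holds the lower of the two numbers and is the stronger inhibitor of the pair. Compound 3 `O=S(=O)(c1ccccc1)n1c(-c2cn(-c3ccccc3)nc2-c2ccc(C(F)(F)F)cc2)nc2ccccc21` has not yet been measured. Its difference from compound 1 is trifluoromethyl in place of methyl on an aromatic carbon, so that 4-methylphenyl becomes 4-(trifluoromethyl)phenyl.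

Among the compounds with values here, only one measured step bears on this change, and only loosely. It is a 6.3-fold higher number from compound 1 to compound 2 (0.80 log units; beyond the scatter), for fluoro in place of hydrogen on an aromatic carbon. Within the data shown here, that modest step lies on a different ring, and no measured compound shows any change at the methyl itself. The direction is therefore carried over from compound 2 with caution, and a smaller step of the same sign is expected in this assay. The expected change is a 2.4-fold higher number from compound 1 to compound 3 (0.38 log units; beyond the scatter), and it remains an uncertain estimate. For compound 3 the estimated value is 2000 nM, with an expected range from 450 nM to 8000 nM.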

Compound 3, half-maximal inhibitory concentration: 630 nM
The estimate for compound 3 lay 3.2-fold (0.50 log units) above the measured number; low and high end bracket the measured number.
By their numbers in this assay, from the lowest: compounds 3 and 1 (each within the scatter of the next); then compound 2.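

In this assay, turning 4-methylphenyl into 4-(trifluoromethyl)phenyl gives a 1.3-fold lower number from compound 1 to compound 3 (0.12 log units; within the scatter) and so leaves compound 1 and compound 3 indistinguishable in this read-out. Within the data shown here, this is the first measured change at this position. Among these compounds, the only earlier step, a 6.3-fold higher number from compound 1 to compound 2 (0.80 log units; beyond the scatter) for fluoro in place of hydrogen, lay on a different ring, and its direction and size did not carry over to this site, where a group of 4 heavy atoms takes the place of a group of 1 heavy atom with no step beyond the scatter. Nothing among the available data accounts for this result or for the contrast between the two steps.

One exchange cannot show whether this position accepts substituents in general, since both groups compared here carry no hydrogen-bond donors or acceptors and no net charge, and an amine, a carboxylic acid or a longer alkyl chain at the same place could behave quite differently. Going by these compounds, it also remains open whether the same exchange would leave the number as little moved on the fluoro-bearing compound 2 as it does on compound 1.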